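Sulfonyl aryl exchange from compound 3 to compound 4

The compounds below may be only part of what the source reports. "The series", "measured", "known", "first", "only" and "open" are said of these compounds alone.

In an ADME assay on HEK293 cells (Homo sapiens) for cytotoxicity, read by resazurin assay, with a stated time of 48 h (on this read-out lower numbers stand for higher toxicity in this test and higher numbers for lower toxicity in this test), compound 3 (`Cc1ccccc1S(=O)(=O)Nc1ccc(-c2nc3ccccc3o2)cc1`) stands at > 100000 nM and this is a limit of the assay, not a number. Compound 1 (`O=S(=O)(Nc1ccc(-c2nc3ccccc3o2)cc1)c1cccc(F)c1`) gives > 100000 nM as a limit too. Compound 2 (`C=Cc1ccc(S(=O)(=O)Nc2ccc(-c3nc4ccccc4o3)cc2)cc1`) gives > 100000 nM as a limit too.

Compound 4 (`O=S(=O)(Nc1ccc(-c2nc3ccccc3o2)cc1)c1ccc(Cl)c(Cl)c1`) carries 3,4-dichlorophenyl in place of 2-methylphenyl on a sulfonyl sulfur and awaits measurement. Going by the values given here, the exchanges at this same place are the steps that bear on it. These are a step that the two limits leave unreadable from compound 1 to compound 3 and a step that the two limits leave unreadable from compound 2 to compound 3 and a step that the two limits leave unreadable from compound 1 to compound 2 and none of them yields a size. All three compounds sit at the limit of > 100000 nM in this assay, at which 3 of the 3 values shown sit, and so the series offers no measured effect of this exchange to carry over.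

No step beyond the scatter is therefore expected in this assay and a reading at the same limit is the likeliest outcome. The expected step is a number no higher from compound 3 to compound 4 (the limit leaves the size open) on this estimate. For compound 4 the estimated value is 100000 nM with an expected range from 30000 nM to 150000 nM as the working estimate.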

Compound 4, half-maximal cytotoxic concentration: > 100000 nM
Compound 4: a limit, no number (the forecaster's own chance of this, stated with the estimate: 70%); the middle value lies on the limit itself.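

In this assay, going by these compounds alone, compound 4 gives > 100000 nM, a limit and not a number, so no step from compound 1, compound 2 or compound 3 to compound 4 can be read. All four share one reading: the limit of > 100000 nM in this assay, at which 4 of the 4 values shown sit.

The compounds shown leave open whether any aryl exchange on the sulfonyl sulfur would give a measurable value in this assay.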